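The compounds below may be only part of what the source reports. "The series", "measured", "known", "first", "only" and "open" are said of these compounds alone.

Measured compounds:
Compound 1 `Cc1cccc(C(=O)c2ccn(-c3ccc4c(c3)B(O)OC4)c2)c1`: > 10 ug/mL
Compound 2 `CC(=O)OCc1ccc(C(=O)c2ccn(-c3ccc4c(c3)B(O)OC4)c2)cc1`: 10 ug/mL

Going by the values given here, in an ADME assay on L929 cells (Mus musculus) for cytotoxicity, read by resazurin assay, with a stated time of 72 h (on this read-out lower numbers stand for stronger inhibition and higher numbers for weaker inhibition), compound 2 gives 10 ug/mL, the only plain number among the two values shown. Compound 1 gives > 10 ug/mL, which is a limit of the assay rather than a number. Compound 3 `O=C(c1ccc(CO)cc1)c1ccn(-c2ccc3c(c2)B(O)OC3)c1` is not yet measured. It differs from compound 2 by hydrogen in place of acetyl on an oxygen on a saturated carbon. Among the compounds with values here, no comparison between measured compounds exists to size this kind of change. The step is expected to stay within the usual scatter, a 1.2-fold higher number from compound 2 to compound 3 (0.08 log units; within the scatter). Compound 3 is estimated at 12 ug/mL, within 4 ug/mL to 30 ug/mL.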

Compound 3, half-maximal inhibitory concentration: 9.31 ug/mL
Estimate against measurement, compound 3: 1.3-fold (0.11 log units) above; measured number inside the range.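

In this assay, hydrogen in place of acetyl on an oxygen on a saturated carbon gives a 1.1-fold lower number from compound 2 to compound 3 (0.03 log units; within the scatter), so acetoxymethyl and hydroxymethyl read alike at this position. The change from 3-methylphenyl to 4-(hydroxymethyl)phenyl on the carbonyl carbon gives an at least 1.0-fold lower number from compound 1 to compound 3 (0.03 log units; that floor lies within the scatter), which rests on a limit rather than a number and sets no order between the two groups. Compound 1 is the compound at that limit: the limit of > 10 ug/mL in this assay, at which 1 of the 3 values shown sits.

Still open, on these data alone, is whether an amine or a carboxylic acid in place of the hydroxymethyl group would shift the reading. As far as these compounds go, a longer chain at this position is equally open.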